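Swapping the Thiourea End for a Dichlorophenyl Group

A few compounds are considered here, and "the series" means these few. Any claim that something is new, unique, unknown or untested is made for them only; others in the source may bear on it.

- Compound 1 `O=S(=O)(NCCNC(=S)Nc1cccc(Cl)c1)c1ccc(-c2ccccc2OCc2cccc(O)c2)s1` gives 5800 nM as a measured number
- Compound 2 `COc1ccc(Oc2ccc([N+](=O)[O-])cc2-c2ccsc2S(=O)(=O)N2CCN(C(=S)Nc3ccc(Cl)cc3)CC2)cc1OC` gives > 50000 nM as a limit of the assay
- Compound 3 `O=S(=O)(NCCNC(=S)Nc1cccc(Cl)c1)c1ccc(-c2ccccc2OCc2ccccc2)s1` gives > 50000 nM as a limit of the assay

All of these results come from a functional assay on RS4-11 cells (Homo sapiens) for inhibition, read by CCK-8 assay, with a stated time of 48 h (a higher number here means a weaker inhibitor, a lower number a stronger inhibitor), and only one of them is a true number. Compound 3 reads > 50000 nM and this is a limit, not a measured number. On these data alone, compound 3 therefore rests on the limit of > 50000 nM in this assay, at which 2 of the 3 values shown sit, and its real position is unknown.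

Compound 4 `O=C(NCCNS(=O)(=O)c1ccc(-c2ccccc2OCc2ccccc2)s1)Nc1cc(Cl)cc(Cl)c1` keeps the core of compound 3 and differs by a group of 11 heavy atoms (7 carbon, 1 nitrogen, 1 oxygen, 2 chlorine; one six-membered aromatic ring of carbon only) in place of a group of 10 heavy atoms (7 carbon, 1 nitrogen, 1 sulfur, 1 chlorine; one six-membered aromatic ring of carbon only), on an amine nitrogen and the entering group is (3,5-dichlorophenyl)carbamoyl.

Within the data shown here, the only measured step, an at least 8.6-fold higher number from compound 1 to compound 3 (0.93 log units; beyond the scatter), swaps a hydroxy for hydrogen and is a different change from this one. Among the measured compounds shown here, it shows only that one small change can matter in this set. For the measured compounds named here, no measured step covers the present swap, so the direction is a cautious guess, and a modest move toward a lower number in this assay is expected. The estimated step is an at least 1.6-fold lower number from compound 3 to compound 4 (0.22 log units; that floor lies within the scatter) and it is rough. For compound 4 the estimated value is 30000 nM with an expected range from 6000 nM to 60000 nM in this assay, and a reported limit remains quite possible.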

Compound 4, half-maximal inhibitory concentration: > 20000 nM
Compound 4: no number, only a limit; the forecaster's own chance of this, stated with the estimate: 50%; the middle value is on the limit's open side.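

Among these compounds, compound 3 and compound 4 both rest on limits in this assay rather than on measured numbers, so no step between them can be read. The compounds shown leave open whether the (3,5-dichlorophenyl)carbamoyl group on the amine nitrogen moves the real value in either direction, and by how much.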